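This account rests on a few compounds, and the source may have more. Where it says the series, first, only, none or still open, it means among the compounds named here.

In an ADME assay on L02 cells (Homo sapiens) for cytotoxicity, read by MTT assay, with a stated time of 48 h (on this read-out higher numbers stand for weaker inhibition and lower numbers for stronger inhibition), compound 1 `CCn1c(C(=O)NCCN(C)C)ccc1C(CC)(CC)c1ccc(OCC(=O)C(C)(C)C)c(C)c1` gives 2500 nM and compound 2 `CCN(CC)CCNC(=O)c1ccc(C(CC)(CC)c2ccc(OCC(O)C(C)(C)C)c(C)c2)n1CC` gives 2500 nM while compound 3 `CCn1c(C(=O)NCCN(C)C)ccc1C(CC)(CC)c1ccc(OCC(O)C(C)(C)C)c(C)c1` gives 2600 nM so compound 3 stands level with both, within the scatter. Putting 1-hydroxy-2,2-dimethylpropyl in place of (tert-butyl)carbonyl gives a 1.0-fold higher number from compound 1 to compound 3 (0.02 log units; within the scatter) and putting dimethylamino in place of diethylamino gives a 1.0-fold higher number from compound 2 to compound 3 (0.02 log units; within the scatter) so neither step goes beyond the scatter. Compound 4 `CCn1c(C(=O)N(CCC#N)CCC#N)ccc1C(CC)(CC)c1ccc(OCC(O)C(C)(C)C)c(C)c1` brings a group of 9 heavy atoms (6 carbon, 3 nitrogen; no ring) in place of a group of 6 heavy atoms (4 carbon, 2 nitrogen; no ring), on a carbonyl carbon on a carbonyl carbon. Neither measured step replaces a whole group of this kind, so both are weak guides. A moderately higher number, meaning weaker inhibition, is only a cautious expectation, and the estimated size is a 1.9-fold higher number from compound 3 to compound 4 (0.28 log units; within the scatter) with wide uncertainty. Compound 4 is estimated at 5000 nM with an expected range from 1500 nM to 20000 nM on this read-out.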

Compound 4, half-maximal inhibitory concentration: 1700 nM
Compound 4: the middle estimate sits 2.9-fold (0.47 log units) above what was measured, within the range that was stated.
By their numbers in this assay, from the lowest: compounds 4, 1, 2 and 3 (each within the scatter of the next).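

Replacing the (2-(dimethylamino)ethyl)amino group on the carbonyl carbon with a larger, nitrile-bearing group that has no hydrogen-bond donors gives a 1.5-fold lower number from compound 3 to compound 4 (0.18 log units; within the scatter) in this assay, and replacing the diethylamino counterpart gives a 1.5-fold lower number from compound 2 to compound 4 (0.17 log units; within the scatter). The earlier steps shown here changed only the ends of the amine, whereas these exchange the whole group and still stay within the scatter. Nothing here offers an explanation for this. On these data alone, it remains open whether a carboxylic acid or a morpholine ring at this carbonyl carbon would also stay level.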